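Swapping the Aryl Group on a Thiourea Nitrogen

This account rests on a few compounds, and the source may have more. Where it says the series, first, only, none or still open, it means among the compounds named here.

Compound 1 `NC(=O)c1c(NC(=O)c2ccccc2Cl)sc2c1CCNC2` and compound 2 `NC(=O)c1c(NC(=O)c2ccccc2Cl)sc2c1CCN(C(=S)Nc1ccccc1I)C2` share one core and differ only at an amine nitrogen in a ring. In a functional assay on HL-60 cells (Homo sapiens) for antiproliferative activity, with a stated time of 24 h (on this read-out higher numbers stand for weaker inhibition and lower numbers for stronger inhibition), compound 1 gives 18600 nM, while compound 2 gives 4430 nM. For the measured compounds named here, the only measured step is a 4.2-fold lower number from compound 1 to compound 2 (0.62 log units; beyond the scatter). On these two numbers compound 2 stands lowest, with compound 1 as its sole, higher neighbour.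

Compound 3 `NC(=O)c1c(NC(=O)c2ccccc2Cl)sc2c1CCN(C(=S)Nc1c(Cl)cccc1Cl)C2` keeps the whole framework of compound 2 and alters a single group: 2,6-dichlorophenyl in place of 2-iodophenyl on an amide-type nitrogen. Going by the values given here, no measured step speaks to this exchange. The step from compound 1 to compound 2 concerns the presence or absence of the entire appended group rather than the identity of the aryl ring on the amide-type nitrogen, so it offers no guide to the size or direction of the present change. Among the compounds with values here, with only that one step in hand, the expectation for compound 3 is of no movement beyond the scatter in this assay. Compound 3 is therefore expected to give 4000 nM, within a range from 1500 nM to 12000 nM. This estimate amounts to an expected 1.1-fold lower number from compound 2 to compound 3 (0.04 log units; within the scatter).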

Compound 3, half-maximal inhibitory concentration: 3950 nM
Compound 3: middle estimate off by 1.0-fold (0.01 log units), on the high side, within the range that was stated.
By their numbers in this assay, from the lowest: compounds 3 and 2 (each within the scatter of the next); then compound 1.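

In this assay, 2,6-dichlorophenyl in place of 2-iodophenyl on the amide-type nitrogen gives a 1.1-fold lower number from compound 2 to compound 3 (0.05 log units; within the scatter), so this exchange of one halogen-bearing aryl group for another leaves the read-out unresolved from that of compound 2. The appended group still counts as a whole in its new form: placing it on the amine nitrogen in the ring gives a 4.7-fold lower number from compound 1 to compound 3 (0.67 log units; beyond the scatter), and like a 4.2-fold lower number from compound 1 to compound 2 (0.62 log units; beyond the scatter) this step lies beyond the scatter, so the two aryl forms of the group are alike in carrying the read-out away from that of compound 1. No measurement at hand explains why these two aryl groups read alike at this place.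

The compounds shown leave open how far this indifference extends on the amide-type nitrogen, since every aryl group here carries halogen, and a plain phenyl, a methoxyphenyl or a simple butyl chain could read differently. They also leave open whether the thiocarbonyl carbon itself matters, which a carbonyl in its place would test with either aryl group.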